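The compounds below may be only part of what the source reports. "The series", "measured", "known", "first", "only" and "open" are said of these compounds alone.

Notes on the series around the shared core. In an ADME assay on GES1 cells (Homo sapiens) for inhibition, read by MTT assay, with a stated time of 72 h (a higher number here means a weaker inhibitor, a lower number a stronger inhibitor), compound 1 `Cc1cc(Nc2cc(-c3ccccc3)[nH]n2)n2nc(SCc3ccc(F)cc3)nc2n1` gives 35500 nM. Compound 2 `Cc1cc(Nc2cc(-c3ccccc3)[nH]n2)n2nc(SCc3c(Cl)cccc3Cl)nc2n1` gives 39600 nM, and the step of a 1.1-fold higher number from compound 1 to compound 2 (0.05 log units; within the scatter) lies within the scatter. Compound 3 `Cc1cc(Nc2cc(-c3ccccc3)[nH]n2)n2nc(SCc3cccc(Br)c3)nc2n1` gives > 50000 nM, which is a limit of the assay and not a number. The steps that reach it are an at least 1.4-fold higher number from compound 1 to compound 3 (0.14 log units; that floor lies within the scatter) and an at least 1.2-fold higher number from compound 2 to compound 3 (0.10 log units; that floor lies within the scatter), and both are known only as floors.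

Compound 4 `Cc1cc(Nc2cc(-c3ccccc3)[nH]n2)n2nc(SCc3ccccc3Br)nc2n1` has yet to be measured. It has the same atoms as compound 3, joined differently: 2-bromophenyl in place of 3-bromophenyl on a saturated chain carbon bound to a sulfur. That is 2-bromophenyl in place of 3-bromophenyl on a saturated chain carbon bound to a sulfur.

Among the measured compounds shown here, no measured step is this exact change. All three measured steps exchange the aryl group at that same place, so they are the ones that bear on it. For the measured compounds named here, the only one with two true numbers, the step to compound 2, is a 1.1-fold higher number from compound 1 to compound 2 (0.05 log units; within the scatter). On that basis, no step beyond the scatter is expected in this assay, and no direction is favoured. The expected step is an at least 1.1-fold lower number from compound 3 to compound 4 (0.07 log units; that floor lies within the scatter). For compound 4 the estimated value is 42000 nM, with an expected range from 26000 nM to 65000 nM. A report of only a limit is also expected to be quite possible.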

Compound 4, half-maximal inhibitory concentration: 41100 nM
Compound 4: the middle estimate sits 1.0-fold (0.01 log units) above what was measured, and the stated range covers the measured number.
By their numbers in this assay, from the lowest: compounds 1, 2 and 4 (each within the scatter of the next). At a limit, above all of these: compound 3.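

With 2-bromophenyl in place of 3-bromophenyl on a saturated chain carbon bound to a sulfur, this assay gives an at least 1.2-fold lower number from compound 3 to compound 4 (0.08 log units; that floor lies within the scatter), so this change is known only as a floor, and that floor does not tell the two bromophenyl groups apart. The entry for compound 3 is a limit of the assay and not a number: the limit of > 50000 nM in this assay, at which 1 of the 4 values shown sits. At this place the 2-bromophenyl group does give a true number, and the steps to it, a 1.0-fold higher number from compound 2 to compound 4 (0.02 log units; within the scatter) and a 1.2-fold higher number from compound 1 to compound 4 (0.06 log units; within the scatter), leave 2-bromophenyl, 2,6-dichlorophenyl and 4-fluorophenyl not told apart in this assay.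

From the compounds shown here alone, whether 3-bromophenyl truly differs from the other three aryl groups stays open, since its only entry is a limit. Every group shown at this place is a halogen-bearing phenyl, so the compounds leave open how the series would read with an amine or a carboxylic acid on that phenyl, or with a longer chain between the sulfur and the ring.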